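The source may report more compounds than this note shows. Statements on the series, on what has been measured and on what is new or still open speak of the compounds shown alone.

Working notes on the series. Among the compounds with values here, compound 1 `CCOC(=O)[C@@H]1[C@@H](C(=O)OCC)N1C(=O)[C@@H]1CCCN(C(=O)[C@H](CC(C)C)NC(=O)OC(C)(C)C)C1` is the only member with a result. In a functional assay on J774 cells (Mus musculus) for cytotoxicity, with a stated time of 48 h (a higher number here means a weaker inhibitor, a lower number a stronger inhibitor), compound 1 gives only the limit of the assay, > 100000 nM. Compound 2 `CC(C)C[C@H](NC(=O)OC(C)(C)C)C(=O)N1CCC(C(=O)N2[C@H](C(=O)O)[C@H]2C(=O)O)CC1` has no result in this assay, "not determined" (no result reported). Compound 3 `CCOC(=O)[C@@H]1[C@@H](C(=O)OCC)N1C(=O)[C@H]1CCCN(C(=O)[C@H](CC(C)C)NC(=O)OC(C)(C)C)C1` differs from compound 1 only in configuration: the two compounds have the same atoms and bonds and differ only in configuration as drawn: 1 of 4 stereo elements differ; a stereocentre at a saturated ring carbon is drawn R in compound 1 and S in compound 3. Within the data shown here, no step between two measured compounds exists, and the one value for compound 1 rests at the limit of > 100000 nM in this assay, at which 1 of the 2 values shown sits. With nothing leaving or entering, the expected step is none beyond the scatter, a number no higher from compound 1 to compound 3 (the limit leaves the size open). Compound 3 is expected at 100000 nM, within 30000 nM to 300000 nM, most likely reported again as a limit.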

Compound 3, half-maximal inhibitory concentration: > 100000 nM
Compound 3: no number, only a limit (the forecaster's own chance of this, stated with the estimate: 75%); the middle value sits exactly at the limit.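

In this assay no step can be read between compound 1 and compound 3, as both results are limits and not numbers: the limit of > 100000 nM in this assay, at which 2 of the 3 values shown sit.

From the compounds shown here alone, whether the stereocentre at a saturated ring carbon, drawn R in compound 1 and S in compound 3, changes the read-out in this assay stays open.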